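Aryl urea series: HepG2 cytotoxicity working notes

The source may hold more compounds than are shown below. What is called first, only, known or untested is meant among the compounds shown, and "the series" means these compounds.

Measured compounds:
compound 1, `CC(=O)c1ccc(NC(=O)Nc2cc(C)nc3ccccc23)cc1` — 19000 nM
compound 2, `Cc1cc(NC(=O)Nc2cccc3nsnc23)c2ccccc2n1` — > 25000 nM

In an ADME assay on HepG2 cells (Homo sapiens) for cytotoxicity, with a stated time of 72 h (a higher number here means that more compound is needed for the effect, a lower number that less compound is needed), compound 1 gives 19000 nM. For compound 2 this assay reports only a limit, > 25000 nM; the relevant point is the limit of > 25000 nM in this assay, at which 1 of the 2 values shown sits. Among the compounds with values here, compound 1 therefore stands as the only numerical value in this assay, with the single other entry being a limit, so no step between measured compounds can be stated.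

Compound 3, `Cc1cc(NC(=O)Nc2ccc(O)cc2)c2ccccc2n1`, is not yet measured. Relative to compound 1 the change is hydroxy in place of acetyl on an aromatic carbon. Within the data shown here, with no measured step to lean on, the expectation for this assay is a step of modest size, if any, in the direction of more compound needed, or none beyond the usual scatter.

Compound 3 is estimated at 25000 nM in this assay, with a range of 9000 nM to 60000 nM. The step of a 1.3-fold higher number from compound 1 to compound 3 (0.12 log units; within the scatter) is expected to be small.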

Compound 3, half-maximal effective concentration: > 25000 nM
Compound 3: a limit, no number; the forecaster's own chance of this, stated with the estimate: 50%; the middle value sits exactly at the limit.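

Hydroxy in place of acetyl, on an aromatic carbon para to a large group, gives the first step that can be read in this series: an at least 1.3-fold higher number from compound 1 to compound 3 (0.11 log units; that floor lies within the scatter). In this assay, within the data shown here, this change at this position does not bring the number down, so the one numerical value is not lowered by replacing the acetyl. Only the floor of the step is known, and that floor does not separate the two compounds beyond the scatter, so its true size stays unfixed: the limit of > 25000 nM in this assay, at which 2 of the 3 values shown sit.

The compounds shown leave open how far past the limit compound 3 lies. They also leave open whether an amine, a carboxylic acid or a longer chain on the same aromatic carbon would give a number rather than a limit.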